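This account rests on a few compounds, and the source may have more. Where it says the series, first, only, none or still open, it means among the compounds named here.

Measured so far in an ADME assay on microsomes from liver (Homo sapiens) for metabolic stability (on this read-out lower numbers stand for a shorter-lived compound and higher numbers for a longer-lived compound), are these two compounds:
- compound 1 `CC(C)C(c1ccc(-c2ccc3cccc(F)c3c2)[nH]c1=O)C1SC(=O)NC1=O` gives 1.87 h
- compound 2 `CC(C)C(CC1NC(=O)NC1=O)c1ccc(-c2ccc3cccc(F)c3c2)[nH]c1=O` gives 1.59 h

Compound 2 lies within the scatter of compound 1, so neither stands apart. Compound 3 `CC(C)C(c1ccc(-c2ccc3cccc(F)c3c2)[nH]c1=O)C1C(=O)NC(=O)N1C` differs from compound 2 by 3-methyl-2,5-dioxoimidazolidin-4-yl in place of (2,5-dioxoimidazolidin-4-yl)methyl on a saturated chain carbon bound to an aromatic carbon and a saturated chain carbon with 3-methyl-2,5-dioxoimidazolidin-4-yl in place of (2,5-dioxoimidazolidin-4-yl)methyl on a saturated chain carbon. For the measured compounds named here, the one measured step that bears on this, a 1.2-fold lower number from compound 1 to compound 2 (0.07 log units; within the scatter) and also a swap at that carbon, stayed small. Going by the values given here, no measured step covers this exact change, so in this assay no step beyond the scatter is expected. The estimated step is a 1.1-fold lower number from compound 2 to compound 3 (0.03 log units; within the scatter) and lies within that scatter. For compound 3 the expected value is 1.5 h with an estimated range from 0.7 h to 3 h in this read-out.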

Compound 3, half-life: 0.375 h
Compound 3: middle estimate off by 4.0-fold (0.60 log units), on the high side; the measured number lies below the stated range.
By their numbers in this assay, from the lowest: compound 3; then compounds 2 and 1 (each within the scatter of the next).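

At the saturated chain carbon bound to an aromatic carbon and a saturated chain carbon, this assay does respond to the group attached: 3-methyl-2,5-dioxoimidazolidin-4-yl gives a 4.2-fold lower number from compound 2 to compound 3 (0.63 log units; beyond the scatter) and a 5.0-fold lower number from compound 1 to compound 3 (0.70 log units; beyond the scatter) at this place. Compound 2 and compound 3 have the same atoms. They differ only in how those atoms are joined. No measurement given here accounts for this step.

The compounds shown leave open whether the methyl or the direct attachment of the ring matters more. Unmethylated 2,5-dioxoimidazolidin-4-yl at this carbon would separate the two.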